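Isopropoxy to Acetyl on the Fused Ring: Compound 4

The source may hold more compounds than are shown below. What is called first, only, known or untested is meant among the compounds shown, and "the series" means these compounds.

The measured compounds and their maximal responses:
compound 1, `CC#C[C@@H](CC(=O)O)c1ccc(OC[C@H]2COc3ccc(F)cc3O2)cc1`, 86%
compound 2, `CC#C[C@@H](CC(=O)O)c1ccc(OC[C@H]2COc3ccc(OC)cc3O2)cc1`, 91%
compound 3, `CC#C[C@@H](CC(=O)O)c1ccc(OC[C@H]2COc3ccc(OC(C)C)cc3O2)cc1`, 90%

In a functional assay on HEK293 cells for agonist activity at Free fatty acid receptor 1 (Homo sapiens), read by fluorescence and calcium flux, with a stated time of 10 min (a lower number here means a smaller maximal response, a higher number a larger maximal response), compound 3 stands second highest of the three numbers, within the usual scatter of both neighbours: a number 1 percentage points lower from compound 2 to compound 3 (within the scatter), and a number 4 percentage points higher from compound 1 to compound 3 (within the scatter). Compound 4, `CC#C[C@@H](CC(=O)O)c1ccc(OC[C@H]2COc3ccc(C(C)=O)cc3O2)cc1`, has not been measured. It differs from compound 3 at one place: acetyl in place of isopropoxy on an aromatic carbon.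

For the measured compounds named here, three steps bear on this position. a number 5 percentage points higher from compound 1 to compound 2 (within the scatter); a number 4 percentage points higher from compound 1 to compound 3 (within the scatter); a number 1 percentage points lower from compound 2 to compound 3 (within the scatter). Every exchange at this aromatic carbon so far, fluoro to methoxy, fluoro to isopropoxy, methyl to isopropyl on the oxygen, has left the maximal response within the scatter. Going by the values given here, none of the measured compounds carries an acetyl group, so the new group itself is untested. On the evidence of these three steps, compound 4 is expected to show no step beyond the scatter, with a number 2 percentage points lower from compound 3 to compound 4 (within the scatter). Compound 4 is therefore estimated at 88%, with a range from 74% to 98%.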

Compound 4, largest response reached (Emax), in percent of the reference or control that the assay uses: 51%
Compound 4: the middle estimate sits 37 percentage points above what was measured, outside the stated range (below it).
By their numbers in this assay, from the lowest: compound 4; then compounds 1, 3 and 2 (each within the scatter of the next).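

In this assay, for the compounds shown here, this aromatic carbon turns out not to tolerate every group: acetyl in place of isopropoxy gives a number 39 percentage points lower from compound 3 to compound 4 (beyond the scatter), acetyl in place of methoxy gives a number 40 percentage points lower from compound 2 to compound 4 (beyond the scatter), and acetyl in place of fluoro gives a number 35 percentage points lower from compound 1 to compound 4 (beyond the scatter), the first steps at this position to lie beyond the scatter. Fluoro, methoxy and isopropoxy stay within the scatter of one another, so the tolerance seen among those three does not extend to acetyl, which brings a double bond outside aromatic rings to this carbon. Nothing available here accounts for the size of this drop.

From the compounds shown here alone, it remains open whether the drop belongs to the carbonyl or to acetyl as a whole. The compounds shown do not tell how an amide, a nitrile or a 1-hydroxyethyl group on this carbon would behave.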